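Shifting a Trifluoromethyl Group Within One Phenyl Ring

A few compounds are considered here, and "the series" means these few. Any claim that something is new, unique, unknown or untested is made for them only; others in the source may bear on it.

Compound 1 `CN(C(=O)NC(=O)c1cccc(C(F)(F)F)c1)c1nc(C(F)(F)F)c(C(=O)N/N=C/c2cccc(C(F)(F)F)c2)s1`: 8.16 ug/mL
Compound 2 `CN(C(=O)NC(=O)c1ccc([N+](=O)[O-])cc1)c1nc(C(F)(F)F)c(C(=O)N/N=C/c2cccc(C(F)(F)F)c2)s1`: 5.42 ug/mL
Compound 3 `CN(C(=O)NC(=O)c1c(F)cccc1F)c1nc(C(F)(F)F)c(C(=O)N/N=C/c2cccc(C(F)(F)F)c2)s1`: 27.6 ug/mL

These numbers come from a functional assay on A549 cells (Homo sapiens) for inhibition, read by MTT assay, with a stated time of 72 h; on this read-out lower numbers stand for stronger inhibition and higher numbers for weaker inhibition. Compound 1 sits second highest of the three: compound 2 lies near it, a 1.5-fold lower number from compound 1 to compound 2 (0.18 log units; within the scatter), while compound 3 lies further off, a 3.4-fold higher number from compound 1 to compound 3 (0.53 log units; beyond the scatter). Compound 4 `CN(C(=O)NC(=O)c1cccc(C(F)(F)F)c1)c1nc(C(F)(F)F)c(C(=O)N/N=C/c2ccc(C(F)(F)F)cc2)s1` differs from compound 1 in one place: 4-(trifluoromethyl)phenyl in place of 3-(trifluoromethyl)phenyl on a carbon with a double bond to nitrogen. Every measured step instead swaps the aryl group on a carbonyl carbon, as in a 5.1-fold higher number from compound 2 to compound 3 (0.71 log units; beyond the scatter); none touches the carbon with a double bond to nitrogen. Nothing measured therefore bears on this change, and no step beyond the scatter is expected in this assay. Compound 4 is estimated at 8.5 ug/mL, ranging from 3.5 ug/mL to 22 ug/mL, which means an expected 1.0-fold higher number from compound 1 to compound 4 (0.02 log units; within the scatter).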

Compound 4, half-maximal inhibitory concentration: 6.2 ug/mL
The estimate for compound 4 lay 1.4-fold (0.14 log units) above the measured number, and the stated range covers the measured number.
By their numbers in this assay, from the lowest: compounds 2, 4 and 1 (each within the scatter of the next); then compound 3.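

Putting 4-(trifluoromethyl)phenyl in place of 3-(trifluoromethyl)phenyl on the carbon with a double bond to nitrogen gives a 1.3-fold lower number from compound 1 to compound 4 (0.12 log units; within the scatter) in this assay. For the compounds shown here, this is the first measured change at this place, and it shows that these two arrangements of the same atoms cannot be told apart in this assay. No available measurement offers an explanation for this result. The compounds shown leave open whether a different group at this place, such as an amine, a carboxylic acid or a longer alkyl chain, would shift the number beyond the scatter.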